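Replacing nitro with hydroxy on an aromatic carbon

This account rests on a few compounds, and the source may have more. Where it says the series, first, only, none or still open, it means among the compounds named here.

In a physicochemical assay, read by spectrophotometry, with a stated time of 30 min (on this read-out higher numbers stand for weaker inhibition and lower numbers for stronger inhibition), compound 2 (`O=C(CCCc1nc2ccccc2c(=O)[nH]1)N/N=C/c1ccc([N+](=O)[O-])cc1`) gives 316000000 nM. Compound 1 (`O=C(CCc1nc2ccccc2c(=O)[nH]1)N/N=C/c1ccc(O)cc1`) gives 238000000 nM, which lies within the scatter of that number, so these two share the upper end of the range. Compound 3 (`COc1cc(/C=N/NC(=O)CCc2nc3ccccc3c(=O)[nH]2)cc(OC)c1O`) gives 126000000 nM, a gap from compound 2 that goes beyond the scatter. Compound 4 (`O=C(CCCc1nc2ccccc2c(=O)[nH]1)N/N=C/c1ccc(O)cc1`) keeps the rest of compound 2 and changes one group: hydroxy in place of nitro on an aromatic carbon. The 4-hydroxyphenyl group also appears in compound 1, at 238000000 nM, although its chain differs. Only a small fall in the number is therefore expected, probably within the scatter, and the estimated step is a 1.6-fold lower number from compound 2 to compound 4 (0.20 log units; within the scatter). Compound 4 is estimated at 200000000 nM, with an expected range of 90000000 nM to 400000000 nM.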

Compound 4, half-maximal inhibitory concentration: 214000000 nM
Estimate against measurement, compound 4: 1.1-fold (0.03 log units) below; low and high end bracket the measured number.
By their numbers in this assay, from the lowest: compounds 3, 4, 1 and 2 (each within the scatter of the next, the first and the last beyond it).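

In this assay, the change of nitro to hydroxy on the aromatic carbon, with the rest of the molecule held fixed, gives a 1.5-fold lower number from compound 2 to compound 4 (0.17 log units; within the scatter). At this position, the read-out therefore does not separate the two groups, even though hydroxy is the smaller group and brings a hydrogen-bond donor that nitro lacks. Nothing available explains this result.

From the compounds shown here alone, whether an amine or a carboxylic acid at this position would also stay within the scatter remains open. So does whether the same change would give a similar step on the chain of compound 1.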